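The source may hold more compounds than are shown below. What is called first, only, known or untested is meant among the compounds shown, and "the series" means these compounds.

Measured so far:
Compound 1, `O=C(NC1CCN(Cc2ccccc2)CC1)c1c(O)c2cccnc2n(-c2ccccc2)c1=O`, 1.7%
Compound 2, `COc1ccc(NC(=O)c2c(O)c3cccnc3n(-c3ccccc3)c2=O)cc1`, 0.3%

Of the compounds shown here, two have been tested in a functional assay on the whole organism for inhibition, with Rattus norvegicus as the target, read by paw edema, at a dose of 100 mg/kg by the oral route; a higher number here means more inhibition at the dose given (going by the name of the read-out), a lower number less inhibition. Compound 1 `O=C(NC1CCN(Cc2ccccc2)CC1)c1c(O)c2cccnc2n(-c2ccccc2)c1=O` gives 1.7% in this assay, and compound 2 `COc1ccc(NC(=O)c2c(O)c3cccnc3n(-c3ccccc3)c2=O)cc1` gives 0.3%. The difference between these two numbers lies within the usual scatter of repeated measurements, so the two compounds cannot be told apart on this assay; both show hardly any inhibition of paw edema at the dose given. Among the compounds with values here, since no step between compounds that differ in one place is recorded, there is nothing in the two values that points to a direction for further change.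

Compound 3 `COc1ccccc1NC(=O)c1c(O)c2cccnc2n(-c2ccccc2)c1=O` has not yet been measured in this assay. Its structure differs from that of compound 2 in one way: 2-methoxyphenyl in place of 4-methoxyphenyl on an amide-type nitrogen. With both measured compounds giving numbers near the bottom of the scale, the step from compound 2 is expected to be a number 2.7 percentage points higher from compound 2 to compound 3 (within the scatter), that is, no change beyond the scatter in either direction. Compound 3 is therefore estimated to give 3% in this assay, with a likely range from 0% to 15%.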

Compound 3, a percentage reported as inhibition, in the whole organism at one dose (the size of the read-out at that dose, not a potency): 8.1%
Compound 3: middle estimate off by 5.1 percentage points, on the low side; low and high end bracket the measured number.
By their numbers in this assay, from the lowest: compounds 2, 1 and 3 (each within the scatter of the next).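

In this assay, within the data shown here, putting 2-methoxyphenyl in place of 4-methoxyphenyl on the amide-type nitrogen gives a number 7.8 percentage points higher from compound 2 to compound 3 (within the scatter), the first step recorded between compounds that differ in one place. It shows that, for these two methoxyphenyl groups, this exchange on the amide-type nitrogen does not separate compound 2 from compound 3: the two cannot be told apart, and neither group lifts the read-out beyond the scatter of the other. Nothing measured here bears on the reason for this result.

The two methoxyphenyl groups are a narrow test of this place, and the compounds shown leave open whether a different group on the amide-type nitrogen, such as an unsubstituted phenyl, a chlorophenyl or a phenyl carrying a carboxylic acid, would give a number beyond the scatter of compound 3. Since the read-out is taken at a single dose and is not a potency, they also leave open how compound 2 and compound 3 would compare at another dose or by another route.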